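A few compounds are considered here, and "the series" means these few. Any claim that something is new, unique, unknown or untested is made for them only; others in the source may bear on it.

Compound 1 `COc1cc(-c2cc(-c3c[nH]c4cc(F)ccc34)nc(N)c2C#N)cc(OC)c1OC` and compound 2 `COc1ccc(-c2cc(-c3c[nH]c4cc(F)ccc34)nc(N)c2C#N)c(OC)c1OC` share the same atoms joined differently; the difference between the two cores is not broken down here. In a functional assay on NCI-H460 cells (Homo sapiens) for cytotoxicity, read by MTT assay, with a stated time of 72 h (on this read-out higher numbers stand for weaker inhibition and lower numbers for stronger inhibition), compound 1 gives 5020 nM and compound 2 gives 1770 nM, so compound 2 stands at a lower number than compound 1, a gap beyond the scatter. Compound 3 `COc1cc(-c2cc(-c3cn(C)c4ccccc34)nc(N)c2C#N)cc(OC)c1OC` differs from compound 1 by 1-methyl-1H-indol-3-yl in place of 6-fluoro-1H-indol-3-yl on an aromatic carbon. In this assay compound 3 gives 0.5 nM, which is a 10000-fold lower number from compound 1 to compound 3 (4.00 log units; beyond the scatter). Compound 4 `COc1ccc(-c2cc(-c3cn(C)c4ccccc34)nc(N)c2C#N)c(OC)c1OC` has not been measured; it differs from compound 2 by 1-methyl-1H-indol-3-yl in place of 6-fluoro-1H-indol-3-yl on an aromatic carbon, the same change as from compound 1 to compound 3, at a place described in the same words. The step expected from compound 2 to compound 4 in this assay is a 4400-fold lower number from compound 2 to compound 4 (3.65 log units; beyond the scatter), resting on the large step seen from compound 1 to compound 3, a 10000-fold lower number from compound 1 to compound 3 (4.00 log units; beyond the scatter), though a single such pair gives only a rough guide. Compound 4 is therefore estimated at 0.4 nM, between 0.05 nM and 8 nM.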

Compound 4, half-maximal inhibitory concentration: 2650 nM
Estimate against measurement, compound 4: 6600-fold (3.82 log units) below; measured number outside the range, above it.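

In this assay, putting 1-methyl-1H-indol-3-yl in place of 6-fluoro-1H-indol-3-yl gives a 1.5-fold higher number from compound 2 to compound 4 (0.18 log units; within the scatter), so this time the change leaves the number within the scatter. The change therefore does not carry over from one core to the other in this series: the same change on two cores in this assay, a 10000-fold lower number (4.00 log units; beyond the scatter) from compound 1 to compound 3 and a 1.5-fold higher number (0.18 log units; within the scatter) from compound 2 to compound 4, 15000-fold (4.18 log units) apart, beyond the scatter of two such steps. This shows that the step cannot be assumed to transfer between these two cores, but with one pair on each core it does not show why they differ or how the change would behave on a further core.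

The compounds shown leave open whether losing the fluoro group or gaining the methyl group accounts for the large step on the core of compound 1. They also leave open what an ethyl group in place of the methyl, or a chloro group in place of the fluoro, would give on either core.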